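Swapping methoxy for methylsulfonyl on the aryl ring

This account rests on a few compounds, and the source may have more. Where it says the series, first, only, none or still open, it means among the compounds named here.

Measured so far:
compound 1 `COc1ccccc1CNc1ncnn1-c1cccc(Cl)c1Cl`: 708 nM
compound 2 `COc1ccc(CNc2ncnn2-c2cccc(Cl)c2Cl)cc1`: 10500 nM

Two compounds share a core and differ only in where a methoxy group sits on the benzyl ring. In a functional assay for antagonist activity at P2X purinoceptor 7 (Rattus norvegicus), read by FLIPR and calcium flux (on this read-out lower numbers stand for stronger inhibition and higher numbers for weaker inhibition), compound 1 gives 708 nM, the lowest number of the two. Compound 2, with the methoxy moved, gives 10500 nM in this assay, a gap that lies beyond the usual scatter.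

Compound 3 `CS(=O)(=O)c1ccccc1CNc1ncnn1-c1cccc(Cl)c1Cl` has not yet been measured. It differs from compound 1 in one place: methylsulfonyl in place of methoxy on an aromatic carbon. No comparison of this kind exists among the measured compounds, so the step can only be guessed. A change of moderate size toward weaker inhibition seems as likely as no change beyond the scatter, so the expected step from compound 1 to compound 3 is a 2.1-fold higher number from compound 1 to compound 3 (0.33 log units; beyond the scatter) in this assay. Compound 3 is therefore estimated at 1500 nM, within a range from 300 nM to 8000 nM.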

Compound 3, half-maximal inhibitory concentration: 39.8 nM
The estimate for compound 3 lay 38-fold (1.58 log units) above the measured number, outside the stated range (below it).
By their numbers in this assay, from the lowest: compound 3; then compound 1; then compound 2.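

In this assay, placing methylsulfonyl in place of methoxy on this aromatic carbon, ortho to a large group, gives an 18-fold lower number from compound 1 to compound 3 (1.25 log units; beyond the scatter) and marks a large move toward stronger inhibition. The earlier pair showed that moving the methoxy around the ring matters, whereas this step shows that the identity of the group on this same carbon matters as well. The site also accepts the methylsulfonyl group, with 4 heavy atoms where methoxy has 2, and inhibition still strengthens; the data at hand offer no explanation for the size of this step.

On these data alone, whether other groups on this carbon, such as a nitrile, a carboxylic acid or an ethylsulfonyl group, would match methylsulfonyl remains open. Also open, as far as these compounds go, is whether methylsulfonyl, moved as the methoxy was in compound 2, would lose inhibition in the same way.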